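Adding an isopropyl group to a weak growth inhibitor

A few compounds are considered here, and "the series" means these few. Any claim that something is new, unique, unknown or untested is made for them only; others in the source may bear on it.

Measured compounds:
Compound 1, `CCC1C(=O)N(C)c2cnc(-n3ccc4cc(C(N)=O)ccc43)nc2N1c1ccn(C)n1`: 27400 nM
Compound 2, `CCC1C(=O)N(C)c2cnc(Nc3ccc(S(=O)(=O)NCCCO)cc3)nc2N1c1ccn(C)n1`: 23700 nM

Both compounds were tested in a functional assay on HeLa cells (Homo sapiens) for antiproliferative activity, read by CCK-8 assay, with a stated time of 72 h; a higher number here means a weaker inhibitor of growth, a lower number a stronger inhibitor of growth. Compound 1 gives 27400 nM, and compound 2 gives 23700 nM. These two numbers lie within the usual scatter of each other, so neither compound can be called the stronger or the weaker inhibitor; both sit at the weak end, far from the concentrations that a potent growth inhibitor would show.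

Compound 3, `CCC1C(=O)N(C)c2cnc(-n3ccc4cc(C(=O)NC(C)C)ccc43)nc2N1c1ccn(C)n1`, has not yet been measured in this assay. It differs from compound 1 in one place: isopropyl in place of hydrogen on an amide-type nitrogen. The shared core and the rest of the molecule are untouched.

Among the measured compounds shown here, no step between two measured compounds exists to show how this kind of change moves the number. For the measured compounds named here, the two measured values say only that the shared core, with either of two very different substituents, gives weak inhibition. The step from compound 1 to compound 3 is therefore expected to be small, a 1.2-fold lower number from compound 1 to compound 3 (0.10 log units; within the scatter), with no clear direction beyond the scatter. Compound 3 is estimated at 22000 nM, within a range from 7000 nM to 65000 nM.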

Compound 3, concentration for 50% growth inhibition: 4350 nM
The estimate for compound 3 lay 5.1-fold (0.70 log units) above the measured number, outside the stated range (below it).
By their numbers in this assay, from the lowest: compound 3; then compounds 2 and 1 (each within the scatter of the next).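

In this assay, the amide-type nitrogen of compound 1 turns out to be a place where a small change registers: isopropyl in place of hydrogen gives a 6.3-fold lower number from compound 1 to compound 3 (0.80 log units; beyond the scatter). Among the compounds shown here, the earlier compounds could not show this, since they differ from each other in more than one place and offered no step to read; they showed only that the shared core gave weak inhibition with two very different substituents. Now one addition of 3 carbon atoms, with the rest of the molecule untouched, moves the number by a modest but readable amount, so the carbamoyl group is not a silent part of compound 1 in this assay. No measurement shown bears on the cause of this step.

Going by these compounds, a single step gives a direction for one group only, so it remains open whether the isopropyl group itself matters or whether any carbon group on this nitrogen would do the same. A methyl group, a longer carbon chain or a chain ending in an amine on the same nitrogen would show whether the number keeps falling, levels off or turns back.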